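Benzyl in place of fluoropropyl: expected cytotoxicity of compound 4

The compounds below may be only part of what the source reports. "The series", "measured", "known", "first", "only" and "open" are said of these compounds alone.

Compound 1, `CCn1nc(C(=O)N[C@H]2COc3ccccc3N(C)C2=S)nc1Cc1ccccc1`: in a toxicity assay on HT-29 cells (Homo sapiens) for cytotoxicity (a lower number here means that less compound is tolerated, a higher number that more compound is tolerated), compound 1 gives > 100000 nM, which is a limit of the assay rather than a number.
Compound 2, `CN1C(=S)[C@@H](NC(=O)c2nc(Cc3ccccc3)n(CCCF)n2)COc2ccccc21`: in this assay compound 2 gives > 100000 nM, again a limit.
Compound 3, `CN1C(=S)[C@@H](NC(=O)c2nc(Cc3ccccc3)n(C3CCCCC3)n2)COc2ccccc21`: in this assay compound 3 gives > 100000 nM, also a limit.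

Compound 2 therefore stands only at a limit, and every measured compound sits at the same one (the limit of > 100000 nM in this assay, at which 3 of the 3 values shown sit). The measured changes a step that the two limits leave unreadable from compound 1 to compound 2, a step that the two limits leave unreadable from compound 1 to compound 3 and a step that the two limits leave unreadable from compound 2 to compound 3 are all unreadable for that reason, so they give no size to carry over.

Compound 4, `CN1C(=S)[C@@H](NC(=O)c2nc(Cc3ccccc3)n(Cc3ccccc3)n2)COc2ccccc21`, differs from compound 2 by phenyl in place of 2-fluoroethyl on a saturated chain carbon bound to an aromatic nitrogen. Since the three neighbours all sit at the limit, no step beyond the scatter is expected in this assay. Compound 4 is estimated at 100000 nM, within 30000 nM to 300000 nM, an expected step of a number no higher from compound 2 to compound 4 (the limit leaves the size open), most likely again reported only as a limit.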

Compound 4, half-maximal cytotoxic concentration: > 100000 nM
Compound 4 ended at the assay's limit; the forecaster's own chance of this, stated with the estimate: 80%; the middle value lies on the limit itself.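

No step can be read between compound 4 and compound 1, compound 2 or compound 3, since all four stand at one limit: the limit of > 100000 nM in this assay, at which 4 of the 4 values shown sit.

Going by these compounds, how far these groups on the aromatic nitrogen differ in this assay stays open.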